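Dropping the hydroxymethyl from a stilbene peptide conjugate

The source may report more compounds than this note shows. Statements on the series, on what has been measured and on what is new or still open speak of the compounds shown alone.

Measured compounds in an ADME assay on Huh-7 cells (Homo sapiens) for cytotoxicity, with a stated time of 24 h; on this read-out higher numbers stand for lower toxicity in this test and lower numbers for higher toxicity in this test:
compound 1 `COc1ccc(/C=C\c2cc(OC)c(OC)c(OC)c2)cc1NC(=O)[C@H](CO)NC(=O)[C@H](CCCNC(=N)N)NC(=O)[C@H](CCCNC(=N)N)NC(=O)c1ccccc1` gives > 100000 nM, a limit of the assay.
compound 2 `COc1ccc(/C=C\c2cc(OC)c(OC)c(OC)c2)cc1NC(=O)CN` gives 173000 nM.
compound 3 `COc1ccc(/C=C\c2cc(OC)c(OC)c(OC)c2)cc1NC(=O)[C@H](CO)NC(=O)[C@H](CCCNC(=N)N)NC(=O)[C@H](CCCCN)NC(=O)c1ccccc1` gives 77900 nM.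

Compound 3 holds the lowest of the two numbers measured, with compound 2 as its nearest neighbour at a higher number that lies beyond the scatter; the value of compound 1 is a limit only. For the measured compounds named here, the one measured step, an at least 1.2-fold lower number from compound 1 to compound 3 (0.10 log units; that floor lies within the scatter), stays within the scatter; it is the case recorded at the limit of > 100000 nM in this assay, at which 1 of the 3 values shown sits, and does not touch the part of the molecule changed next.

Compound 4 `COc1ccc(/C=C\c2cc(OC)c(OC)c(OC)c2)cc1NC(=O)CNC(=O)[C@H](CCCNC(=N)N)NC(=O)[C@H](CCCCN)NC(=O)c1ccccc1` differs from compound 3 by hydrogen in place of hydroxymethyl on a saturated chain carbon bound to an amide-type nitrogen and a carbonyl carbon. Going by the values given here, no measured step in this assay concerns a change at that place, so nothing recorded supports a shift beyond the scatter in either direction. Compound 4 is therefore expected to sit close to compound 3, with a 1.2-fold higher number from compound 3 to compound 4 (0.06 log units; within the scatter) as the expected step. The estimate for compound 4 in this assay is 90000 nM, expected to fall between 40000 nM and 200000 nM.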

Compound 4, half-maximal cytotoxic concentration: > 100000 nM
Compound 4: no number, only a limit (the forecaster's own chance of this, stated with the estimate: 35%); middle value at least 1.1-fold (0.04 log units) away from the limit.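

In this assay compound 4 gives > 100000 nM, which is a limit of the assay and not a number. For the compounds shown here, this is the only measured change of hydroxymethyl to hydrogen on a saturated chain carbon bound to an amide-type nitrogen and a carbonyl carbon, and it gives an at least 1.2-fold higher number from compound 3 to compound 4 (0.10 log units; that floor lies within the scatter), so the direction of any real shift at this place cannot be settled. Removing the hydroxymethyl leaves a compound that, like compound 1, is recorded only at the limit: the limit of > 100000 nM in this assay, at which 2 of the 4 values shown sit.

As far as these compounds go, the true size of the step therefore stays open. Also open, from the compounds shown here alone, is whether a methyl group, an aminomethyl group or a carboxylic acid at this place would give a number that differs from compound 3 beyond the scatter.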